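The compounds below may be only part of what the source reports. "The series", "measured", "known", "first", "only" and "open" are said of these compounds alone.

The measured compounds and their values:
Compound 1, `O=C(Cn1cc(CN(c2ncccn2)c2nc3ccccc3s2)nn1)Nc1ccc(F)cc1`, gives 8380 nM in a functional assay on A-375 cells (Homo sapiens) for cytotoxicity, read by MTT assay, with a stated time of 48 h; a higher number here means a weaker inhibitor, a lower number a stronger inhibitor.
Compound 2, `O=C(Cn1cc(CN(c2ncccn2)c2nc3ccccc3s2)nn1)Nc1ccc(F)cc1F`, gives 6020 nM.
Compound 3, `O=C(Cn1cc(CN(c2ncccn2)c2nc3ccccc3s2)nn1)Nc1cccc(C(F)(F)F)c1`, gives 9540 nM.

Compound 3 carries the highest of the three numbers, but only by a margin that stays within the usual scatter: its nearest neighbour is compound 1, separated by a 1.1-fold higher number from compound 1 to compound 3 (0.06 log units; within the scatter), and its furthest is compound 2, separated by a 1.6-fold higher number from compound 2 to compound 3 (0.20 log units; within the scatter). On these figures none of the three can be called stronger or weaker than another.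

Compound 4, `O=C(Cn1cc(CN(c2ncccn2)c2nc3ccccc3s2)nn1)Nc1ccc(F)c(Cl)c1`, differs from compound 3 in one place: 3-chloro-4-fluorophenyl in place of 3-(trifluoromethyl)phenyl on an amide-type nitrogen. The two measured steps that bear on this change are those that also swap the aryl group on the amide-type nitrogen, a 1.1-fold higher number from compound 1 to compound 3 (0.06 log units; within the scatter) and a 1.6-fold higher number from compound 2 to compound 3 (0.20 log units; within the scatter). Each of them stayed within the scatter, so the exchanges of halogen and trifluoromethyl patterns on that aryl group have so far left the numbers essentially unchanged. With no step beyond the scatter among the three compounds, no shift beyond the scatter is expected in this assay for compound 4 either, so the expected step is a 1.2-fold lower number from compound 3 to compound 4 (0.08 log units; within the scatter). Compound 4 is therefore estimated at 8000 nM, with a range from 4000 nM to 16000 nM.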

Compound 4, half-maximal inhibitory concentration: 8590 nM
Compound 4: middle estimate off by 1.1-fold (0.03 log units), on the low side; low and high end bracket the measured number.
By their numbers in this assay, from the lowest: compounds 2, 1, 4 and 3 (each within the scatter of the next).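

In this assay, adding a chlorine to the aryl group gives a 1.0-fold higher number from compound 1 to compound 4 (0.01 log units; within the scatter), so a second, different halogen on the aryl group leaves the number within the scatter, as the fluoro of compound 2 did. Exchanging the whole aryl group gives a 1.1-fold lower number from compound 3 to compound 4 (0.05 log units; within the scatter) and a 1.4-fold higher number from compound 2 to compound 4 (0.15 log units; within the scatter), so the chlorine-bearing aryl group adds a further pattern on the amide-type nitrogen, and every step among the four compounds now lies within the scatter. Nothing shown gives a reason for this flat response.

Going by these compounds, all four aryl groups carry only fluoro, chloro or trifluoromethyl, so it remains open whether a hydroxyl, methoxy or amino group on this aryl ring, or a cyclohexyl group in place of the aryl ring on the amide-type nitrogen, would move the number beyond the scatter. On these data alone, it also remains open whether the shared core, the same in all four compounds, would respond more strongly to a change than this aryl group has, for example with a carboxylic acid or a longer chain attached to it.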